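One methyl on an amide nitrogen of compound 1

This account rests on a few compounds, and the source may have more. Where it says the series, first, only, none or still open, it means among the compounds named here.

Compound 1 (`CC(C)c1cc(C(=O)Nc2ccc(NC(=O)CCCCCCC(=O)NO)cc2)c(O)cc1O`): 5430 nM
Compound 2 (`CC(C)c1cc(C(=O)Nc2ccccc2NC(=O)CCCCCCC(=O)NO)c(O)cc1O`): 4920 nM

Going by the values given here, both compounds have been measured in a functional assay on HCT-116 cells (Homo sapiens) for inhibition, read by sulforhodamine B assay, with a stated time of 48 h (a higher number here means a weaker inhibitor of growth, a lower number a stronger inhibitor of growth), and their values lie within the usual scatter of each other. Compound 1 therefore does not stand apart from compound 2 on these numbers, and the two together give a first reference level for this series.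

Compound 3 (`CC(C)c1cc(C(=O)N(C)c2ccc(NC(=O)CCCCCCC(=O)NO)cc2)c(O)cc1O`) keeps the core of compound 1 and makes a single change, methyl in place of hydrogen on an amide-type nitrogen. Among the compounds with values here, no two measured compounds differ by this change, so the data offer no direct guide. With so little to go on, no step beyond the scatter is expected, in either direction, and the range must stay wide. The estimated step is small (a 1.4-fold lower number from compound 1 to compound 3 (0.13 log units; within the scatter)). In this assay compound 3 is expected to give an estimated value of 4000 nM (with a range from 1300 nM to 12000 nM).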

Compound 3, concentration for 50% growth inhibition: 830 nM
Compound 3: the middle estimate sits 4.8-fold (0.68 log units) above what was measured; the whole stated range lies above it.
By their numbers in this assay, from the lowest: compound 3; then compounds 2 and 1 (each within the scatter of the next).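

Methyl in place of hydrogen on this amide-type nitrogen gives a 6.5-fold lower number from compound 1 to compound 3 (0.82 log units; beyond the scatter) in this assay, so a single added carbon is enough to move the result beyond the scatter. The amide hydrogen at this place is therefore not required for growth inhibition in these cells, and the position responds to even a small change, which compound 1 and compound 2 could not show on their own. Nothing measured here explains why the methyl has this effect.

The compounds shown do not say whether an ethyl group or a longer chain on this nitrogen would extend the gain or lose it. They also leave open whether the same methyl on the corresponding nitrogen of compound 2 would give a similar step.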